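Amide to urea at the carbonyl of compound 1

The source may report more compounds than this note shows. Statements on the series, on what has been measured and on what is new or still open speak of the compounds shown alone.

Compound 1 `CC(=O)N(C)CC#CCN1CCCC1` is the more active of the two compounds measured in a functional assay on the whole organism for agonist activity, with Mus musculus as the target; on this read-out higher numbers stand for an effect only at larger amounts of compound and lower numbers for an effect already at smaller amounts; in this assay compound 1 gives 0.3 mg/kg. Compound 2 `COC(=O)N(C)CC#CCN(C)C`, which shares the alkyne-linked chain but carries a different acyl group and a different amine end, gives in this assay 17.3 mg/kg, a gap that lies well beyond the scatter. Compound 1 and compound 2 differ in more than one place. No single step can be read from the pair.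

Compound 3 `CN(C)C(=O)N(C)CC#CCN1CCCC1` is not yet measured. It differs from compound 1 in one place: dimethylamino in place of methyl on a carbonyl carbon. The same difference, cut one bond further out, reads acetyl to dimethylcarbamoyl. The data hold no measured step of this kind in this assay, so the expectation rests on compound 1 alone. A modest rise in the number is expected, from compound 1 to compound 3 by a 3.3-fold higher number from compound 1 to compound 3 (0.52 log units; beyond the scatter). Compound 3 is accordingly expected to give 1 mg/kg in this assay, within 0.3 mg/kg to 4 mg/kg.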

Compound 3, dose for half-maximal effect: 1.2 mg/kg
Estimate against measurement, compound 3: 1.2-fold (0.08 log units) below; the measured number falls inside the stated range.
By their numbers in this assay, from the lowest: compound 1; then compound 3; then compound 2.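

Working notes on the carbonyl position: this is the first single-place step in the series, as compound 1 and compound 2 differ in more than one place. In this assay, putting dimethylamino in place of methyl on a carbonyl carbon gives a 4.0-fold higher number from compound 1 to compound 3 (0.60 log units; beyond the scatter), so this position responds to the change, but only by a step labelled modest, and the larger group, with 3 heavy atoms against 1, leaves compound 3 at 1.2 mg/kg, still at a low dose on this read-out. No measured property is available to account for this step, so it stands as an observation only.

The compounds shown give only the two end points of this change, so it remains open whether an ethyl group or an unsubstituted amino group on the same carbonyl carbon would fall nearer to methyl or to dimethylamino. Within the data shown here, it is also open whether the same step would appear with a dimethylamino group at the amine end of the chain, since the single step read here comes from one amine end only.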